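A Carbamoyl Group in Place of the Vinylsulfonyl Group

This account rests on a few compounds, and the source may have more. Where it says the series, first, only, none or still open, it means among the compounds named here.

For the measured compounds named here, compound 2 `C=CS(=O)(=O)N1CCN(c2ncnc3sc(-c4ccc(N5CCN(C)CC5)cc4)cc23)CC1` gives 7550 nM in a functional assay on MDA-MB-231 cells (Homo sapiens) for antiproliferative activity, read by MTT assay, with a stated time of 48 h (on this read-out lower numbers stand for stronger inhibition and higher numbers for weaker inhibition), the second highest of the three numbers known. Compound 1 `C=CS(=O)(=O)N1CCN(c2ncnc3sc(-c4ccc(OC)cc4)cc23)CC1` gives 29900 nM, while compound 3 `C=CS(=O)(=O)N1CCN(c2ncnc3sc(-c4ccc(N5CCN(C)CC5)cc4)cc23)[C@@H](C)C1` gives 6180 nM. The step of a 4.0-fold lower number from compound 1 to compound 2 (0.60 log units; beyond the scatter) is the larger of the two measured steps, and the step of a 1.2-fold lower number from compound 2 to compound 3 (0.09 log units; within the scatter) is the smaller. Compound 4 `CN1CCN(c2ccc(-c3cc4c(N5CCN(C(=O)Nc6ccc(Cl)cc6)CC5)ncnc4s3)cc2)CC1` differs from compound 2 by (4-chlorophenyl)carbamoyl in place of vinylsulfonyl on an amine nitrogen in a ring. Going by the values given here, neither measured step involves the amine nitrogen in a ring where this exchange takes place, so no measured step bears on it directly. Compound 4 is therefore expected to give a number close to that of compound 2, with the step of a 1.5-fold lower number from compound 2 to compound 4 (0.18 log units; within the scatter) expected to stay within the scatter. The estimate for compound 4 is 5000 nM, with a range from 1200 nM to 20000 nM.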

Compound 4, half-maximal inhibitory concentration: 5440 nM
For compound 4 the middle estimate is 1.1-fold (0.04 log units) below the measured one, and the stated range covers the measured number.
By their numbers in this assay, from the lowest: compounds 4, 3 and 2 (each within the scatter of the next); then compound 1.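

In this assay, for the compounds shown here, the step of a 1.4-fold lower number from compound 2 to compound 4 (0.14 log units; within the scatter) gives the first reading at the amine nitrogen in a ring, and it shows that (4-chlorophenyl)carbamoyl, with its six-membered aromatic ring of carbon only, can replace vinylsulfonyl there while the number stays within the scatter. The earlier steps shown here touched only an aromatic carbon and a saturated ring carbon. No measurement at hand accounts for this outcome.

As far as these compounds go, whether the same holds for an acetyl group or a simple alkyl chain on this nitrogen stays open. So does what the chlorine contributes, since an unsubstituted phenylcarbamoyl group is not among the compounds shown.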